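Cytotoxicity notes on the amide series: compound 3 pending

This account rests on a few compounds, and the source may have more. Where it says the series, first, only, none or still open, it means among the compounds named here.

Measured so far:
compound 1, `Cc1ccccc1C(=O)Nc1cc(-c2ccccc2)ccn1`, 70000 nM
compound 2, `Cc1ccccc1C(=O)Nc1cc(C#Cc2ccccc2)ccn1`, 198000 nM

The two measured compounds share one core and differ at a single aromatic carbon. In an ADME assay on L6 cells (Rattus norvegicus) for cytotoxicity, read by resazurin assay, with a stated time of 70 h (a higher number here means a weaker inhibitor, a lower number a stronger inhibitor), compound 1 gives 70000 nM and compound 2 gives 198000 nM. Within the data shown here, the only step so far is a 2.8-fold higher number from compound 1 to compound 2 (0.45 log units; beyond the scatter). Compound 2 therefore stands with the highest number of the two; its nearest neighbour is compound 1, with a lower number beyond the scatter.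

Compound 3, `Cc1ccccc1C(=O)Nc1cc(Cl)ccn1`, is still to be measured in this assay. Relative to compound 2 the change is chloro in place of 2-phenylethynyl on an aromatic carbon. The step of a 2.8-fold higher number from compound 1 to compound 2 (0.45 log units; beyond the scatter) is the one that bears on this, but it concerns one aromatic group swapped for a longer one, not the removal of such a group for chloro, so it carries only loosely. Among the measured compounds shown here, it shows that this position moves the number in a modest way; no step shows a shrink of this size.

For compound 3 a small shift is expected, a 1.3-fold lower number from compound 2 to compound 3 (0.12 log units; within the scatter), most likely within or near the scatter. Compound 3 is estimated at 150000 nM, in the range 50000 nM to 400000 nM.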

Compound 3, half-maximal inhibitory concentration in the L6 assay: 224000 nM
For compound 3 the middle estimate is 1.5-fold (0.17 log units) below the measured one; low and high end bracket the measured number.
By their numbers in the L6 assay, from the lowest: compound 1; then compounds 2 and 3 (each within the scatter of the next).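

In the L6 assay, a 1.1-fold higher number from compound 2 to compound 3 (0.05 log units; within the scatter), so at this aromatic carbon, opposite the ring nitrogen, the change from 2-phenylethynyl to chloro cannot be told apart from no change, while a 3.2-fold higher number from compound 1 to compound 3 (0.51 log units; beyond the scatter) sets compound 1 apart from compound 3 as it was already set apart from compound 2, and the number therefore does not simply follow the size of the group. In a physicochemical assay for solubility, read by nephelometry, measured as kinetic solubility, at pH 6.5, tested at 10 mg/mL (on this read-out lower numbers stand for lower solubility and higher numbers for higher solubility), compound 2 gives < 1.6 ug/mL, which is a limit of the assay and not a number: the limit of < 1.6 ug/mL in the physicochemical assay, at which 1 of the 2 values shown sits. In the physicochemical assay compound 3 gives 12.5 ug/mL, and an at least 7.8-fold higher number from compound 2 to compound 3 (0.89 log units; beyond the scatter), so a pair that stays together on the cytotoxicity read-out separates on this one.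

Open, going by these compounds, is whether the match between compound 2 and compound 3 in the L6 assay would hold for an amine or a carboxylic acid at the same carbon, or whether phenyl in compound 1 stays the lone departure. Also open, on these data alone, is how large the solubility gap really is, and whether a longer chain such as hexyl would follow compound 2 or compound 3.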